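This account rests on a few compounds, and the source may have more. Where it says the series, first, only, none or still open, it means among the compounds named here.

Working notes on the series. Three analogues sharing one core have been tested in a functional assay on BJAB cells (Homo sapiens) for antiproliferative activity, with a stated time of 4 days; a lower number here means that less compound is needed, a higher number that more compound is needed for the effect. Compound 1 `Cc1c(-c2cc(Cl)cc(Cl)c2)c(C(=O)O)nn1-c1nc(-c2cccnc2)c(SC(C)C)s1` carries a pyridin-3-yl group on the five-membered ring with one nitrogen and one sulfur; in this assay compound 1 is recorded as "not active" (no number reported). Going by the values given here, compound 2 `Cc1c(-c2cc(Cl)cc(Cl)c2)c(C(=O)O)nn1-c1nc(-c2cc(Cl)ccc2F)c(SC(C)C)s1` carries a 5-chloro-2-fluorophenyl group in the same position and is the only member for which a number was obtained; in this assay compound 2 gives 4800 nM. Compound 3 `Cc1c(-c2cc(Cl)cc(Cl)c2)c(C(=O)O)nn1-c1nc(-c2cnn(C)c2)c(SC(C)C)s1` carries a 1-methyl-1H-pyrazol-4-yl group there, and in this assay compound 3 is recorded as "not active" (no number reported), so compound 3 stands without a number, alongside compound 1, while only compound 2 gave a measurable value.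

Compound 4 `Cc1c(-c2cc(Cl)cc(Cl)c2)c(C(=O)O)nn1-c1nc(-c2ccncc2)c(SC(C)C)s1` is the next analogue to be measured. Relative to compound 3 the change is pyridin-4-yl in place of 1-methyl-1H-pyrazol-4-yl on an aromatic carbon. Among the compounds with values here, no measured pair in the set differs in only this one place, so no step size can be quoted for it. Since compound 1 and compound 3 both gave no number, and only compound 2 reached a measurable value, compound 4 is expected either to return no number or to give a weak value; the estimate for compound 4 is 15000 nM, with a range from 4000 nM to 60000 nM.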

Compound 4, half-maximal effective concentration: "not active" (no number reported)
The entry for compound 4 holds no number; the estimate stays without a comparison.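

In this assay compound 4, like compound 3, is recorded without a number, so no step can be read between them. No further data bear on this result. The compounds shown leave open how far pyridin-4-yl and 1-methyl-1H-pyrazol-4-yl differ in this assay, and which feature of compound 2 accompanies its measurable value.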